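A few compounds are considered here, and "the series" means these few. Any claim that something is new, unique, unknown or untested is made for them only; others in the source may bear on it.

Compound 1 `CCOC(=O)Cc1nc(N)n(C(=O)c2ccc(OC)cc2)n1` and compound 2 `CCOC(=O)Cc1nc(N)n(C(=O)c2ccc([N+](=O)[O-])cc2)n1` are built on one core, while compound 3 `CCOC(=O)Cc1n[nH]c(NC(=O)c2ccc(OC)cc2)n1` and compound 4 `CCOC(=O)Cc1n[nH]c(NC(=O)c2ccc([N+](=O)[O-])cc2)n1` are built on another. The two cores contain the same atoms joined differently, and how they differ is not broken down here. In a functional assay on the whole organism (strain albino) for inhibition, with Rattus norvegicus as the target, read by paw edema, with stated times of 30 min and 3 h, at a dose of 5 mg/kg by the oral route (on this read-out lower numbers stand for less inhibition and higher numbers for more inhibition at the one dose given (going by the name of the read-out)), compound 1 gives 60% and compound 2 gives 68.2%. The change between them is nitro in place of methoxy on an aromatic carbon and it gave a number 8.2 percentage points higher from compound 1 to compound 2 (within the scatter), a step that stays within the scatter of repeated measurements, so the two numbers cannot be told apart with confidence. On the other core, compound 3 gives 56% in this assay. Within the data shown here, compound 4 has not yet been measured; it differs from compound 3 by nitro in place of methoxy on an aromatic carbon, which is the same change, made at the same place, as the one taking compound 1 to compound 2. Because the earlier step of a number 8.2 percentage points higher from compound 1 to compound 2 (within the scatter) stayed within the scatter, a step of similar size is expected here, a number 8 percentage points higher from compound 3 to compound 4 (within the scatter). Compound 4 is therefore estimated at 64%, with a likely range from 52% to 76% to allow for the scatter of this kind of measurement.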

Compound 4, a percentage reported as inhibition, in the whole organism at one dose (the size of the read-out at that dose, not a potency): 59.8%
Compound 4: middle estimate off by 4.2 percentage points, on the high side, within the range that was stated.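

In this assay, nitro in place of methoxy on an aromatic carbon gave a number 3.8 percentage points higher from compound 3 to compound 4 (within the scatter). Set beside the same change on the other core, the two steps cannot be told apart: the same change on two cores in this assay, a number 8.2 percentage points higher (within the scatter) from compound 1 to compound 2 and a number 3.8 percentage points higher (within the scatter) from compound 3 to compound 4, 4.4 percentage points apart, within the scatter of two such steps This shows that, as far as this read-out can tell, the change carried over from one core to the other without a clear difference, but it does not show that the two steps are truly equal, that the change has a real effect on either core, or that it would behave the same way on any further core.

The compounds shown carry only methoxy or nitro at this spot on the six-membered aromatic ring, so it remains open whether an amine or a chlorine atom there would give a step beyond the scatter on either core. The ethyl ester is also the same in all four compounds, which leaves open how a carboxylic acid or a longer chain in its place would behave on the two cores.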